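A few compounds are considered here, and "the series" means these few. Any claim that something is new, unique, unknown or untested is made for them only; others in the source may bear on it.

Going by the values given here, compound 3 `O=c1c(-c2nn[nH]n2)c[nH]c2c(C(F)(F)F)cccc12` gives 0.156 mg/kg in a functional assay on the whole organism (strain Sprague-Dawley) for inhibition, with Rattus norvegicus as the target (a lower number here means that less compound is needed, a higher number that more compound is needed for the effect), which places it second highest of the three numbers so far, although the gap to compound 2 `COc1cccc2c(=O)c(-c3nn[nH]n3)c[nH]c12` with 0.15 mg/kg lies within the scatter; compound 1 `O=c1c(-c2nn[nH]n2)c[nH]c2ccccc12` with 1.25 mg/kg is the furthest away. Compound 4 `CC(C)c1cccc2c(=O)c(-c3nn[nH]n3)c[nH]c12` differs from compound 3 by isopropyl in place of trifluoromethyl on an aromatic carbon. Among the compounds with values here, the steps that bear on this change are an 8.3-fold lower number from compound 1 to compound 2 (0.92 log units; beyond the scatter), an 8.0-fold lower number from compound 1 to compound 3 (0.90 log units; beyond the scatter) and a 1.0-fold higher number from compound 2 to compound 3 (0.02 log units; within the scatter): replacing hydrogen at this aromatic carbon lowered the number, while exchanging one group for another there left it within the scatter. Given a 1.0-fold higher number from compound 2 to compound 3 (0.02 log units; within the scatter), the step of a 1.3-fold higher number from compound 3 to compound 4 (0.11 log units; within the scatter) is expected to stay within the scatter. Compound 4 is therefore estimated at 0.2 mg/kg, with a range from 0.08 mg/kg to 0.6 mg/kg.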

Compound 4, minimum effective dose: 1.25 mg/kg
For compound 4 the middle estimate is 6.3-fold (0.80 log units) below the measured one; measured number above the stated range.
By their numbers in this assay, from the lowest: compounds 2 and 3 (each within the scatter of the next); then compounds 1 and 4 (each within the scatter of the next).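

At this aromatic carbon the choice of group now matters: isopropyl brings an 8.0-fold higher number from compound 3 to compound 4 (0.90 log units; beyond the scatter) and an 8.3-fold higher number from compound 2 to compound 4 (0.92 log units; beyond the scatter), whereas methoxy and trifluoromethyl had stood within the scatter of each other. With no change at the digits printed from compound 1 to compound 4 (within the scatter), isopropyl does not share the gain over hydrogen seen with those two groups, so replacing hydrogen here does not lower the number in every case. No evidence is available that explains this difference. As far as these compounds go, whether an ethyl group, a chlorine or an amine at this carbon would behave like isopropyl or like trifluoromethyl remains open.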